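The source may report more compounds than this note shows. Statements on the series, on what has been measured and on what is new or still open speak of the compounds shown alone.

Three compounds built on a shared core, in which an amide joins two benzene rings, have been tested in an assay on isolated protein for inhibition of NAD-dependent protein deacylase sirtuin-6 (Homo sapiens), read by fluorescence, tested at 200 uM; a higher number here means more inhibition at the concentration tested (going by the name of the read-out), a lower number less inhibition. Compound 1 `O=C(Nc1ccc(O)c(C(=O)O)c1)c1cccc(N2C(=O)CCS2(=O)=O)c1` gives 54%, and compound 2 `O=C(Nc1ccc(O)c(C(=O)O)c1)c1ccc(NC(=O)C2CC2)cc1` gives 50%. Compound 3 `O=C(Nc1ccc(C(=O)O)c(O)c1)c1cccc(N2C(=O)CCS2(=O)=O)c1`, whose core is closely related, gives 44%. Among these three numbers compound 3 has the lowest, but its gap to compound 2 and its gap to compound 1 both lie within the usual scatter of this kind of measurement, so the three compounds cannot be told apart on these data.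

Compound 4 `O=C(Nc1ccc(C(=O)O)c(O)c1)c1cccc(NC(=O)c2ccco2)c1` has not yet been measured in this assay. It keeps the core of compound 3 and alters a single group: a group of 8 heavy atoms (5 carbon, 1 nitrogen, 2 oxygen; one five-membered aromatic ring with 1 hetero atom) in place of a group of 8 heavy atoms (3 carbon, 1 nitrogen, 3 oxygen, 1 sulfur; one five-membered non-aromatic ring with 2 hetero atoms), on an aromatic carbon. The entering ((furan-2-yl)carbonyl)amino group sits on an aromatic carbon of a six-membered aromatic ring of carbon only, meta to a large group.

Within the data shown here, no measured pair differs in only this one place, so the size of the step has to be guessed. Because compound 1 gives 54% and compound 2 gives 50%, two quite different groups in this part of the molecule yield numbers within the scatter of each other, and the expected step of a number 1 percentage points higher from compound 3 to compound 4 (within the scatter) is likewise estimated to stay within the scatter. Compound 4 is therefore expected to give about 45%, within a range from 25% to 65%.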

Compound 4, a percentage reported as inhibition, at one concentration (the size of the read-out at that concentration, not a potency): 62%
Compound 4: the middle estimate sits 17 percentage points below what was measured; low and high end bracket the measured number.
By their numbers in this assay, from the lowest: compounds 3, 2, 1 and 4 (each within the scatter of the next, the first and the last beyond it).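

In this assay, among these compounds, the change at this aromatic carbon gives a number 18 percentage points higher from compound 3 to compound 4 (beyond the scatter), the first single-place step here that lies beyond the usual scatter, so the group at this place can change the read-out. The number of heavy atoms stays the same across the step, which means that a difference in that count cannot be what separates the two compounds. What does change is the kind of group: a five-membered aromatic ring and a hydrogen-bond donor enter, while a five-membered non-aromatic ring containing sulfur leaves, and nothing measured here explains why the number moves.

These differences all arrive together in one swap, so the compounds shown cannot say which of them matters, and a thiophene ring in place of the furan, or a simple acetylamino group, would help pull them apart. Going by these compounds, it also remains open whether the same swap would give a similar step on the core of compound 1, and how the step would look as a potency rather than as a read-out at one concentration.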